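The Same Benzyl Swap, Tried on a Second Core

The compounds below may be only part of what the source reports. "The series", "measured", "known", "first", "only" and "open" are said of these compounds alone.

Compound 1, `CCC(CC)c1ccc2c(NCCCNCc3cc(F)ccc3OC)ccnc2c1`: 7860 nM
Compound 2, `CCC(CC)c1ccc2c(NCCCNCc3cccc(OC)c3O)ccnc2c1`: 410 nM
Compound 3, `COc1ccc(F)cc1CNCCCNc1ccnc2cc(-c3ccc(C(F)(F)F)cc3)ccc12`: 5190 nM

These three compounds have been tested in an ADME assay on HepG2 cells (Homo sapiens) for cytotoxicity, read by luminescence, CellTiter-Glo and ATP content, with a stated time of 72 h; on this read-out higher numbers stand for an effect only at larger amounts of compound and lower numbers for an effect already at smaller amounts. Compound 2 differs from compound 1 by 2-hydroxy-3-methoxyphenyl in place of 5-fluoro-2-methoxyphenyl on a saturated chain carbon bound to an amine nitrogen, and that change produced a 19-fold lower number from compound 1 to compound 2 (1.28 log units; beyond the scatter). Compound 3 differs from compound 1 by 4-(trifluoromethyl)phenyl in place of pentan-3-yl on an aromatic carbon, a change that produced a 1.5-fold lower number from compound 1 to compound 3 (0.18 log units; within the scatter). For the measured compounds named here, compound 4, `COc1cccc(CNCCCNc2ccnc3cc(-c4ccc(C(F)(F)F)cc4)ccc23)c1O`, has not yet been measured; it differs from compound 3 by 2-hydroxy-3-methoxyphenyl in place of 5-fluoro-2-methoxyphenyl on a saturated chain carbon bound to an amine nitrogen, the same change as the one from compound 1 to compound 2, now made on the core of compound 3 instead of the core of compound 1. Going by the values given here, for compound 4 in this assay a step of about a 15-fold lower number from compound 3 to compound 4 (1.17 log units; beyond the scatter) is expected, resting on the single earlier example a 19-fold lower number from compound 1 to compound 2 (1.28 log units; beyond the scatter) seen on a different core. Compound 4 is therefore estimated at 350 nM, within a likely range from 120 nM to 1200 nM.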

Compound 4, half-maximal effective concentration: 2210 nM
For compound 4 the middle estimate is 6.3-fold (0.80 log units) below the measured one; measured number outside the range, above it.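

On the core of compound 3, the benzyl swap still lowers the number, with a 2.3-fold lower number from compound 3 to compound 4 (0.37 log units; beyond the scatter), but this step is much smaller than on the core of compound 1, so the direction carried over and the size did not: the same change on two cores in this assay, a 19-fold lower number (1.28 log units; beyond the scatter) from compound 1 to compound 2 and a 2.3-fold lower number (0.37 log units; beyond the scatter) from compound 3 to compound 4, 8.2-fold (0.91 log units) apart, beyond the scatter of two such steps

Seen from the other side, replacing pentan-3-yl with 4-(trifluoromethyl)phenyl gives a 5.4-fold higher number from compound 2 to compound 4 (0.73 log units; beyond the scatter) when the 2-hydroxy-3-methoxyphenyl group is present, unlike the step within the scatter seen with 5-fluoro-2-methoxyphenyl: the same change on two cores in this assay, a 1.5-fold lower number (0.18 log units; within the scatter) from compound 1 to compound 3 and a 5.4-fold higher number (0.73 log units; beyond the scatter) from compound 2 to compound 4, 8.2-fold (0.91 log units) apart, beyond the scatter of two such steps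

So the two changes do not simply add up in these four compounds, but the data do not show why, or how the swap would behave on any further core.

From the compounds shown here alone, it remains open whether another group on that aromatic carbon, such as a plain phenyl or a cyclohexyl ring, would give the large step or the small one. Going by these compounds, it is also open whether a benzyl group carrying only the hydroxy group would behave like 2-hydroxy-3-methoxybenzyl.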